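A few compounds are considered here, and "the series" means these few. Any claim that something is new, unique, unknown or untested is made for them only; others in the source may bear on it.

Compound 1 `CNc1ncc2c(-c3ccc(N4CCNCC4)nc3)nn(CC3CCCC3)c2n1`: in an assay for inhibition of tyrosine-protein kinase receptor TYRO3 (Homo sapiens), read by 33P incorporation, in the presence of a further agent that is not named here (on this read-out higher numbers stand for weaker inhibition and lower numbers for stronger inhibition), compound 1 gives > 10000 nM, which is a limit.
Compound 2 `CNc1ncc2c(-c3ccc(N4CCNCC4)nc3)nn(Cc3cn(Cc4ccccc4)nn3)c2n1`: in this assay compound 2 gives > 10000 nM, which is a limit.
Compound 3 `CNc1ncc2c(-c3ccc(N4CCNCC4)nc3)nn(Cc3cn(-c4ccsc4C(=O)OC)nn3)c2n1`: in this assay compound 3 gives > 10000 nM, which is a limit.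

Compound 2 stands, like the other two, at the limit of this assay; no number is known for it, only that it sits at the limit. Compound 4 `CNc1ncc2c(-c3ccc(N4CCN(C)CC4)nc3)nn(Cc3cn(Cc4ccccc4)nn3)c2n1` differs from it by methyl in place of hydrogen on an amine nitrogen in a ring.

Two measured steps sit near this change, but neither can be read: a step that the two limits leave unreadable from compound 1 to compound 2 and a step that the two limits leave unreadable from compound 2 to compound 3, because of the limit of > 10000 nM in this assay, at which 3 of the 3 values shown sit. Within the data shown here, both of those steps alter the group on the saturated chain carbon bound to the aromatic nitrogen or the group on the triazole nitrogen, not the piperazine; no measured step touches the amine nitrogen in the ring, so the size of the present change has no direct precedent. With every value shown at the limit, there is nothing to support an expectation of a readable step, and the expected outcome for the step from compound 2 to compound 4 is a step that the limit leaves unreadable from compound 2 to compound 4, that is, a value that is most likely again at the limit. Compound 4 is accordingly estimated at 15000 nM in this assay, with a range from 4000 nM to 60000 nM.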

Compound 4, half-maximal inhibitory concentration: > 10000 nM
Compound 4 ended at the assay's limit; the forecaster's own chance of this, stated with the estimate: 85%; the middle value is on the limit's open side.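

No new step can be read: compound 2 and compound 4 both stand at a limit, so methyl in place of hydrogen on the amine nitrogen has no readable size, because the comparison rests on limits alone: the limit of > 10000 nM in this assay, at which 4 of the 4 values shown sit.

The compounds shown leave open whether piperazin-1-yl and 4-methylpiperazin-1-yl differ at all in this assay, and which change to the shared core would yield a number rather than a limit.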